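The source may hold more compounds than are shown below. What is called first, only, known or untested is meant among the compounds shown, and "the series" means these compounds.

This study centres on compound 1 `C[Se]/C(=N\C(=O)c1sccc1Cl)NC(=O)c1sccc1Cl`, in which two identical carbonyl-bearing arms are joined through a carbon that carries a double bond to nitrogen and holds a selenium-containing group. Among the compounds with values here, in an ADME assay on MCF-10A cells (Homo sapiens) for cytotoxicity, read by MTT assay, with a stated time of 72 h (a higher number here means a weaker inhibitor of growth, a lower number a stronger inhibitor of growth), compound 1 gives 5490 nM, the lowest of the two numbers measured so far. Within the data shown here, the only other measured member is compound 2 `CS/C(=N\C(=O)c1ccco1)NC(=O)c1ccco1`, which differs from compound 1 both in its rings and in the group on that carbon. In this assay compound 2 gives 46500 nM, a gap that lies well beyond the scatter. Compound 2 changes two places at once, so this gap cannot be credited to either change alone.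

Compound 3 `CS/C(=N\C(=O)c1sccc1Cl)NC(=O)c1sccc1Cl` keeps the ring-bearing arms of compound 1 and alters a single spot: a group of 2 heavy atoms (1 carbon, 1 sulfur; no ring) in place of a group of 2 heavy atoms (1 carbon, 1 selenium; no ring), on a carbon with a double bond to nitrogen. Among the measured compounds shown here, no measured pair shows this exchange on its own. Compound 2 also carries the methylsulfanyl group and gives 46500 nM, which leaves room for some weakening. The step of a 2.2-fold higher number from compound 1 to compound 3 (0.34 log units; beyond the scatter) is therefore expected to be modest, towards a higher number. For compound 3 the expected value is 12000 nM, with a range from 4000 nM to 40000 nM.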

Compound 3, concentration for total growth inhibition: 23700 nM
Compound 3: middle estimate off by 2.0-fold (0.30 log units), on the low side; the range from low to high includes it.
By their numbers in this assay, from the lowest: compound 1; then compounds 3 and 2 (each within the scatter of the next).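

Within the data shown here, this is the first exchange seen on its own: with the ring-bearing arms held fixed, putting methylsulfanyl in place of the selenium-containing group, on a carbon with a double bond to nitrogen, gives a 4.3-fold higher number from compound 1 to compound 3 (0.64 log units; beyond the scatter). So in this assay this one spot matters by itself, and the selenium-containing group of compound 1 goes with the stronger inhibition of growth, a link that compound 2 could not show since it changes two places at once. Compound 3 at 23700 nM and compound 2 at 46500 nM, which both carry methylsulfanyl, lie within the scatter of each other, and no measurement shown here explains why swapping selenium for sulfur has this effect.

Whether the exchange has the same size on the arms of compound 2 stays open, as no selenium-bearing partner of compound 2 is among the compounds shown. Also open, going by these compounds, is how this carbon would respond to a longer chain such as ethylsulfanyl, or to an amine in the same place.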